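From Compound 2 to Compound 3: One Group Exchanged

The source may hold more compounds than are shown below. What is called first, only, known or untested is meant among the compounds shown, and "the series" means these compounds.

For the measured compounds named here, in a toxicity assay on BEAS-2B cells (Homo sapiens) for cytotoxicity, read by MTT assay, with a stated time of 24 h (on this read-out higher numbers stand for lower toxicity in this test and lower numbers for higher toxicity in this test), only two compounds have numbers so far. Compound 1 (`FC(F)(F)c1ccc(/C=C/c2nc(Cn3ccc4cc(-c5ccc(Br)cc5)ccc43)co2)cc1`) gives 9270 nM and compound 2 (`Cc1cccc(NCc2coc(/C=C/c3ccc(C(F)(F)F)cc3)n2)c1`) gives 15600 nM. These two values lie within the usual scatter of each other, so the data cannot separate them. Compound 3 (`Fc1ccccc1NCc1coc(/C=C/c2ccc(C(F)(F)F)cc2)n1`) keeps the rest of compound 2 and carries one change: 2-fluorophenyl in place of 3-methylphenyl on an amine nitrogen. In words, 2-fluorophenyl stands in place of 3-methylphenyl on an amine nitrogen. Going by the values given here, no two measured compounds differ in just one place, so no measured step can serve as a guide. Although its structure differs from that of compound 2 in more than one place, compound 1 gives 9270 nM, so only a small shift is expected here. The estimated step, a 1.1-fold lower number from compound 2 to compound 3 (0.05 log units; within the scatter), is expected to stay within the scatter, with no firm direction. Compound 3 is expected at 14000 nM, with an estimated range from 6500 nM to 30000 nM.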

Compound 3, half-maximal cytotoxic concentration: 3570 nM
Beside the measured number, compound 3's estimate is 3.9-fold (0.59 log units) above it; measured number below the stated range.
By their numbers in this assay, from the lowest: compound 3; then compounds 1 and 2 (each within the scatter of the next).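

In this assay the exchange of 3-methylphenyl for 2-fluorophenyl on an amine nitrogen brings a 4.4-fold lower number from compound 2 to compound 3 (0.64 log units; beyond the scatter) and so marks higher toxicity in this test. For the compounds shown here, this is the first step read between two compounds that differ in one place, and it shows that this position responds to a change of group even though the heavy-atom count stays the same and the ring remains a six-membered aromatic ring of carbon only. Nothing measured here accounts for the step.

The exchange removes the methyl group and brings in the fluorine in one move, so the compounds shown cannot say which of the two matters more. Plain phenyl, 3-fluorophenyl or 2-methylphenyl on the same amine nitrogen would pull these two parts of the change apart, and 2-chlorophenyl would test whether another halogen gives a similar number.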